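Lengthening the amine chain on a flavone core

A few compounds are considered here, and "the series" means these few. Any claim that something is new, unique, unknown or untested is made for them only; others in the source may bear on it.

Measured compounds:
compound 1 `CCN(CC)CCCCOc1c(OC)cc2oc(-c3ccccc3)cc(=O)c2c1O` gives 35000 nM
compound 2 `O=c1cc(-c2ccccc2)oc2cc(OCc3ccccc3)c(OCCCN3CCCC3)c(O)c12` gives 1400 nM
compound 3 `CN(C)CCCOc1c(OCc2ccccc2)cc2oc(-c3ccccc3)cc(=O)c2c1O` gives 2600 nM

These three compounds share a core and were tested in a functional assay on A549 cells (Homo sapiens) for antiproliferative activity, read by MTT assay, with a stated time of 48 h; on this read-out lower numbers stand for stronger inhibition and higher numbers for weaker inhibition. Compound 3 holds the second highest of the three numbers; its nearest neighbour is compound 2, which differs from it by a 1.9-fold higher number from compound 2 to compound 3 (0.27 log units; within the scatter), a step within the scatter, while compound 1 stands far apart with a number beyond the scatter. Compound 4 `CCN(CC)CCCCOc1c(OCc2ccccc2)cc2oc(-c3ccccc3)cc(=O)c2c1O` has not yet been measured in this assay. It differs from compound 3 by (diethylamino)methyl in place of dimethylamino on a saturated chain carbon, three bonds along the chain from an oxygen on an aromatic ring. For the measured compounds named here, the only step measured so far that touches the amine end of the chain is the one from compound 2 to compound 3, and it was within the scatter. Going by the values given here, compound 1 carries the same (diethylamino)butyl chain as compound 4 but differs at a second place too, so no single step relates it to compound 4. Because compound 1 gives 35000 nM, a modest weakening is expected: compound 4 is estimated at 4500 nM, ranging from 1300 nM to 15000 nM, an expected step of a 1.7-fold higher number from compound 3 to compound 4 (0.24 log units; within the scatter).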

Compound 4, half-maximal inhibitory concentration: 1800 nM
The estimate for compound 4 lay 2.5-fold (0.40 log units) above the measured number; the measured number falls inside the stated range.
By their numbers in this assay, from the lowest: compounds 2, 4 and 3 (each within the scatter of the next); then compound 1.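

In this assay, replacing 3-(dimethylamino)propyl with 4-(diethylamino)butyl gives a 1.4-fold lower number from compound 3 to compound 4 (0.16 log units; within the scatter), and replacing the pyrrolidine-ended chain with 4-(diethylamino)butyl gives a 1.3-fold higher number from compound 2 to compound 4 (0.11 log units; within the scatter), so the longer diethylamino chain keeps compound 4 level with both. With that chain held fixed, phenyl in place of hydrogen on a saturated chain carbon bound to an oxygen on an aromatic ring gives a 19-fold lower number from compound 1 to compound 4 (1.29 log units; beyond the scatter), which shows that the chain alone does not carry the weak number of compound 1. No measurement available here accounts for these steps.

As far as these compounds go, the step from compound 3 to compound 4 alters chain length and the amine's alkyl groups together, so their separate contributions remain unknown. Also open, from the compounds shown here alone, is how a morpholine at the chain end, or a chain longer than butyl, would behave.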